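The source may hold more compounds than are shown below. What is called first, only, known or untested is meant among the compounds shown, and "the series" means these compounds.

Going by the values given here, compound 1 `Cn1cc(-c2ccccc2F)c2cc(C(=O)NCc3ccc(C(=O)Nc4ccccc4N)cc3)[nH]c2c1=O` holds the lowest of the two numbers so far. In a functional assay on MV4-11 cells (Homo sapiens) for antiproliferative activity, read by CCK-8 assay, with a stated time of 72 h (a higher number here means a weaker inhibitor, a lower number a stronger inhibitor), compound 1 gives 230 nM. Compound 2 `Cn1cc(-c2ccccc2Oc2ccccc2)c2cc(C(=O)NCc3ccc(C(=O)NO)cc3)[nH]c2c1=O` gives 570 nM in this assay, a gap from compound 1 that lies beyond the scatter. Compound 3 `COc1ccc(-c2cn(C)c(=O)c3[nH]c(C(=O)NCc4ccc(C(=O)Nc5ccccc5N)cc4)cc23)cc1` differs from compound 1 in one place: 4-methoxyphenyl in place of 2-fluorophenyl on an aromatic carbon. Among the compounds with values here, no measured pair shows this change, so its effect is unknown; a small step, likely within the scatter and in either direction, is expected as a 1.2-fold higher number from compound 1 to compound 3 (0.09 log units; within the scatter). In this assay compound 3 is therefore estimated at 280 nM, within a range of 110 nM to 700 nM.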

Compound 3, half-maximal inhibitory concentration: 320 nM
The estimate for compound 3 lay 1.1-fold (0.06 log units) below the measured number; low and high end bracket the measured number.
By their numbers in this assay, from the lowest: compounds 1, 3 and 2 (each within the scatter of the next, the first and the last beyond it).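

In this assay, 4-methoxyphenyl in place of 2-fluorophenyl on this aromatic carbon gives a 1.4-fold higher number from compound 1 to compound 3 (0.14 log units; within the scatter) and so shows that this position tolerates this swap, which brings in one hydrogen-bond acceptor and one more heavy atom, with no change beyond the scatter. Nothing available explains this outcome. Still open, from the compounds shown here alone, is whether a group without an aromatic ring, such as an amine, a carboxylic acid or a longer chain, would hold the number at this position. Also open, going by these compounds, is whether a plain phenyl would do the same.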